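This account rests on a few compounds, and the source may have more. Where it says the series, first, only, none or still open, it means among the compounds named here.

In an ADME assay on microsomes from liver (Homo sapiens) for metabolic stability (on this read-out lower numbers stand for a shorter-lived compound and higher numbers for a longer-lived compound), two compounds have been measured so far. Compound 1 `CC(C)C(/C=C1\NC(=O)NC1=O)c1ccc(-c2ccc3cccc(F)c3c2)[nH]c1=O` stands at > 3 h and this is a limit of the assay and not a number. Compound 2 `O=C1NC(=O)/C(=C/C(c2ccc(-c3ccc4cccc(F)c4c3)[nH]c2=O)C2CCCCC2)O1` gives 1.09 h as the only actual number shown, which makes it the sole numeric reference for what follows. Going by the values given here, no measured pair differing in one place is available, so no measured step guides the next comparison.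

Compound 3 `O=C1NC(=O)/C(=C/C(c2ccccc2)c2ccc(-c3ccc4cccc(F)c4c3)[nH]c2=O)O1` departs from compound 2 in one place by the change phenyl in place of cyclohexyl on a saturated chain carbon bound to an aromatic carbon and a double-bonded chain carbon and nowhere else. A six-membered non-aromatic ring of carbon only thus gives way to a six-membered aromatic ring of carbon only. With nothing measured on this exchange, the expectation in this assay is a small step upward that stays within the usual scatter. The expected change is a 1.4-fold higher number from compound 2 to compound 3 (0.14 log units; within the scatter) as an estimate and no more. Compound 3 is expected at 1.5 h with an estimated range from 0.7 h to 3 h for repeated measurements.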

Compound 3, half-life: 2.1 h
Estimate against measurement, compound 3: 1.4-fold (0.15 log units) below; the range from low to high includes it.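

In this assay, going by these compounds alone, phenyl in place of cyclohexyl on a saturated chain carbon bound to an aromatic carbon and a double-bonded chain carbon gives the first step that can be read at this position: a 1.9-fold higher number from compound 2 to compound 3 (0.28 log units; within the scatter). The read-out therefore does not separate the six-membered aromatic ring of carbon only from the six-membered non-aromatic ring of carbon only, and this position accepts either ring with no change beyond what repeated measurements would show. This single pair cannot say how far a change at this position could carry the half-life, and the upper end of the scale shown here is itself a limit of the assay and not a number: the limit of > 3 h in this assay, at which 1 of the 3 values shown sits.

Compound 1 differs from compound 2 in more than one place, so its limit cannot be credited to the smaller isopropyl group at this carbon or to any other single change. The compounds shown leave open whether a ring carrying nitrogen such as pyridine, a basic amine, a carboxylic acid or a longer straight chain at this same carbon would move the half-life beyond the scatter.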